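Acyl chain branching in the ester series on K562 cells

A few compounds are considered here, and "the series" means these few. Any claim that something is new, unique, unknown or untested is made for them only; others in the source may bear on it.

Measured compounds:
Compound 1, `CCCC(=O)OCCCCOC(=O)c1ccc(C(=O)Nc2ccc3c(c2)C(C)(C)CCC3(C)C)cc1`: in a functional assay on K562 cells (Homo sapiens) for inhibition, read by MTT assay, with a stated time of 48 h (on this read-out higher numbers stand for weaker inhibition and lower numbers for stronger inhibition), compound 1 gives 92600 nM.
Compound 2, `CCCC(=O)OCCOC(=O)c1ccc(C(=O)Nc2ccc3c(c2)C(C)(C)CCC3(C)C)cc1`: compound 2 gives 18600 nM.
Compound 3, `C=C(c1ccc(C(=O)OCCOC(=O)c2ccc(C(=O)Nc3ccc4c(c3)C(C)(C)CCC4(C)C)cc2)cc1)c1cc2c(cc1C)C(C)(C)CCC2(C)C`: compound 3 gives 504000 nM.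

Compound 2 gives the lowest number of the three in this assay; compound 1 and compound 3 both read higher, each by more than the usual scatter. Among the measured compounds shown here, the one single-point step measured is a 5.0-fold lower number from compound 1 to compound 2 (0.70 log units; beyond the scatter), a shortening of the linker on the alcohol side of the ester.

Compound 4, `CCCC(CCC)C(=O)OCCOC(=O)c1ccc(C(=O)Nc2ccc3c(c2)C(C)(C)CCC3(C)C)cc1`, is not yet measured. It differs from compound 2 by 1-propylbutyl in place of propyl on a carbonyl carbon, that is, propylcarbonyl becomes (1-propylbutyl)carbonyl while the linker and core stay as in compound 2. For the measured compounds named here, no measured step touches this carbonyl carbon; the step from compound 1 to compound 2 concerns the other side of the ester, and compound 3 shows only that a large replacement elsewhere carries a much higher number. Going by the values given here, with no step bearing directly on the change, the expectation is a step of about a 1.4-fold higher number from compound 2 to compound 4 (0.15 log units; within the scatter) in this assay, close to the scatter, perhaps toward a somewhat higher number. Compound 4 is therefore estimated at 26000 nM, with a range from 8000 nM to 85000 nM.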

Compound 4, half-maximal inhibitory concentration: 664000 nM
Compound 4: middle estimate off by 26-fold (1.41 log units), on the low side, and the stated range ends below it.
By their numbers in this assay, from the lowest: compound 2; then compound 1; then compounds 3 and 4 (each within the scatter of the next).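

In this assay, among the compounds shown here, the substituent on this carbonyl carbon matters a great deal: 1-propylbutyl in place of propyl gives a 36-fold higher number from compound 2 to compound 4 (1.55 log units; beyond the scatter) and is the first measured step at this position. Read against the longer linker, the change gives a 7.2-fold higher number from compound 1 to compound 4 (0.86 log units; beyond the scatter) and is also beyond the scatter, so the gain from the shorter linker does not carry over to the 1-propylbutyl ester. No measured evidence at hand accounts for the size of these steps.

Still open, as far as these compounds go, is whether the higher number goes with the branch in 1-propylbutyl or with the added carbons alone: a straight heptyl chain on the same carbonyl carbon would separate the two. Open too, from the compounds shown here alone, is how a shorter acyl group, such as acetyl, or an amine-bearing acyl chain would read here.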